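A few compounds are considered here, and "the series" means these few. Any claim that something is new, unique, unknown or untested is made for them only; others in the source may bear on it.

Compound 2 `Cc1nn(-c2ccccc2)cc1/C=N/Nc1nc(Nc2ccccc2)nc(Nc2ccc(S(N)(=O)=O)cc2)n1` holds the lower of the two numbers in a functional assay on SK-MEL-28 cells (Homo sapiens) for inhibition, read by sulforhodamine B assay, with a stated time of 48 h (a higher number here means that more compound is tolerated, a lower number that less compound is tolerated), where compound 2 gives 6640 nM; compound 1 `NS(=O)(=O)c1ccc(Nc2nc(N/N=C/c3ccc(C(F)(F)F)cc3)nc(Nc3ccccc3)n2)cc1` gives 26300 nM, and the step is a 4.0-fold lower number from compound 1 to compound 2 (0.60 log units; beyond the scatter). Compound 3 `NS(=O)(=O)c1ccc(Nc2nc(N/N=C/c3ccccn3)nc(Nc3ccccc3)n2)cc1` carries the change (pyridin-2-yl in place of 3-methyl-1-phenyl-1H-pyrazol-4-yl on a carbon with a double bond to nitrogen). Among the measured compounds shown here, the only measured step at this carbon, a 4.0-fold lower number from compound 1 to compound 2 (0.60 log units; beyond the scatter), shows that exchanging the ring there can shift the number by a modest amount, but no measured compound carries a pyridin-2-yl at this position, so the direction is uncertain. The expected step is a 1.7-fold higher number from compound 2 to compound 3 (0.22 log units; within the scatter), a small move upward. Compound 3 is therefore estimated at 11000 nM, within 3000 nM to 40000 nM.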

Compound 3, concentration lethal to 50% of the cells: 6190 nM
For compound 3 the middle estimate is 1.8-fold (0.25 log units) above the measured one, and the stated range covers the measured number.
By their numbers in this assay, from the lowest: compounds 3 and 2 (each within the scatter of the next); then compound 1.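

On a carbon with a double bond to nitrogen, replacing 3-methyl-1-phenyl-1H-pyrazol-4-yl with pyridin-2-yl, a group of 6 rather than 12 heavy atoms, gives a 1.1-fold lower number from compound 2 to compound 3 (0.03 log units; within the scatter) in this assay, so a single aromatic ring serves as well here as the two-ring group. Replacing 4-(trifluoromethyl)phenyl with pyridin-2-yl gives a 4.2-fold lower number from compound 1 to compound 3 (0.63 log units; beyond the scatter), so two different nitrogen-containing groups now share this edge over compound 1. No measurement here explains either step. As far as these compounds go, whether any ring is needed on this carbon stays open, as does the outcome with a simple amine or a carboxylic acid there.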